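Methoxy in Place of Fluoro Where Every Value Is a Limit

The compounds below may be only part of what the source reports. "The series", "measured", "known", "first", "only" and "open" are said of these compounds alone.

Compound 3 `CCCNNC(=O)c1ccc(CNC(=O)c2cc3cc(F)ccc3[nH]2)cc1` stands at a limit in an assay on isolated protein for inhibition of protein deacetylase HDAC6 (Homo sapiens), read by fluorescence, with a stated time of 2 h; a lower number here means a stronger inhibitor, a higher number a weaker inhibitor: compound 3 gives > 10000 nM, which is a limit of the assay rather than a number. Compound 1 `CCCNNC(=O)c1ccc(CNC(=O)c2cc3ccccc3[nH]2)cc1` likewise gives > 10000 nM in this assay, again a limit. Compound 2 `CCCNNC(=O)c1ccc(CNC(=O)c2nc3ccccc3[nH]2)cc1` also stands at a limit, giving > 10000 nM. Because all three values sit at the limit of > 10000 nM in this assay, at which 3 of the 3 values shown sit, the single-change step from compound 1 to compound 3, a step that the two limits leave unreadable from compound 1 to compound 3, cannot be read. Compound 4 `CCCNNC(=O)c1ccc(CNC(=O)c2cc3cc(OC)ccc3[nH]2)cc1` differs from compound 3 by methoxy in place of fluoro on an aromatic carbon. Among the measured compounds shown here, no measured step shows what this change does. Compound 4 is therefore expected to remain at the limit, with an estimated step that the limit leaves unreadable from compound 3 to compound 4. The estimate for compound 4 in this assay is 15000 nM, expected to fall between 4000 nM and 60000 nM.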

Compound 4, half-maximal inhibitory concentration: > 10000 nM
Compound 4: no number, only a limit (the forecaster's own chance of this, stated with the estimate: 85%); the middle value does not contradict the limit.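

Compound 4, like compound 3 and compound 1, gives only a limit in this assay, so no new step among them can be read: the limit of > 10000 nM in this assay, at which 4 of the 4 values shown sit.

The compounds shown leave open whether methoxy in place of fluoro changes inhibition at all, and how strong any of these four compounds is.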